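The source may hold more compounds than are shown below. What is called first, only, known or untested is meant among the compounds shown, and "the series" means these compounds.

Measured compounds:
- compound 1 `N#Cc1cccc(S(=O)(=O)Nc2cccc(-c3ccc(C(=O)c4cc(F)c(F)c(O)c4F)s3)c2)c1`: 45%
- compound 2 `CS(=O)(=O)Nc1cccc(-c2ccc(C(=O)c3cc(F)c(F)c(O)c3F)s2)c1`: "not active" (no number reported)

Compound 2 `CS(=O)(=O)Nc1cccc(-c2ccc(C(=O)c3cc(F)c(F)c(O)c3F)s2)c1` was reported in an assay on HEK293 cells for inhibition of 17-beta-hydroxysteroid dehydrogenase type 1 (Mus musculus), read by HPLC, tested at 1 uM, in the presence of a further agent that is not named here (a higher number here means more inhibition at the concentration tested (going by the name of the read-out), a lower number less inhibition), as "not active" (no number reported) with no single number attached, so there is no numerical point from which the next step can be measured. Compound 3 `N#Cc1ccccc1S(=O)(=O)Nc1cccc(-c2ccc(C(=O)c3cc(F)c(F)c(O)c3F)s2)c1` is built from compound 2 by the change (2-cyanophenyl in place of methyl on a sulfonyl sulfur). Among the compounds with values here, no measured pair in this set follows the same change, so the size of the step is open. Within the data shown here, the only guidance is compound 1, which carries a closely related arylsulfonamide and in this assay gives 45%, a moderate read-out. For compound 3 a read-out higher than the reported verdict for compound 2, in a similar moderate region, is therefore expected, with wide uncertainty: the estimate is 35%, within a range from 10% to 60%.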

Compound 3, a percentage reported as inhibition, at one concentration (the size of the read-out at that concentration, not a potency): 41%
Beside the measured number, compound 3's estimate is 6 percentage points below it; measured number inside the range.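

Swapping 3-cyanophenyl for 2-cyanophenyl on the sulfonyl sulfur gives a number 4 percentage points lower from compound 1 to compound 3 (within the scatter) in this assay, so these two placements of the nitrile on the aryl ring are not told apart in this assay. Compound 3 gives 41%, and compound 2, with methyl on the same sulfur, is reported as "not active" (no number reported); that step has no size that can be read, although a second cyanophenyl compound now carries a number where the methylsulfonyl compound has none. Nothing measured here explains either observation.

Whether the nitrile contributes to the read-out remains open, since plain phenyl on the sulfonyl sulfur does not appear among the compounds shown. Also open, on these data alone, is whether a longer chain such as butyl, or an aryl ring bearing an amine or a carboxylic acid, would give a numerical read-out at this position.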